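This account rests on a few compounds, and the source may have more. Where it says the series, first, only, none or still open, it means among the compounds named here.

The study sets two cores side by side, each carrying the same ethyl ester and methoxy group. Compound 1 `CCOC(=O)c1c(-c2ccccc2)[nH]c2cc(OC)ccc2c1=O` and compound 3 `CCOC(=O)c1c(-c2ccccc2)[nH]c2cccc(OC)c2c1=O` are built from the same atoms, joined differently; the difference between the two cores is not broken down here. Compound 2 `CCOC(=O)c1c(-c2ccccc2Cl)[nH]c2cc(OC)ccc2c1=O` is compound 1 with chloro in place of hydrogen on an aromatic carbon. Compound 4 `CCOC(=O)c1c(-c2ccccc2Cl)[nH]c2cccc(OC)c2c1=O`, which has not yet been measured, is compound 3 with chloro in place of hydrogen on an aromatic carbon; the surroundings of the place are described in the same words for both pairs, so it is the same change made on the other core.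

In a physicochemical assay for solubility, in phosphate buffer, at pH 7.4 (a higher number here means a more soluble compound, a lower number a less soluble compound), compound 1 gives only a limit of the assay, > 100000 nM. Compound 3 in this assay also gives a limit, > 100000 nM. Compound 2 in this assay gives 28000 nM. The measured step is an at least 3.5-fold lower number from compound 1 to compound 2 (0.55 log units; beyond the scatter); only a lower bound on its size can be given because the limit of > 100000 nM in this assay, at which 2 of the 3 values shown sit, is where compound 1 stands.

For compound 4 the same change is expected to bring a drop similar to that seen on the first core, an at least 3.3-fold lower number from compound 3 to compound 4 (0.52 log units; beyond the scatter). This expectation rests on an at least 3.5-fold lower number from compound 1 to compound 2 (0.55 log units; beyond the scatter) and on compound 3 sitting at a limit in this assay, so that the true size of the step cannot be fixed. Compound 4 is thus estimated at 30000 nM in this assay, within a range from 10000 nM to 90000 nM.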

Compound 4, solubility: > 100000 nM
Compound 4: only a limit was reported; the forecaster's own chance of this, stated with the estimate: 10%; middle value at least 3.3-fold (0.52 log units) from the limit.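

Compound 4 gives > 100000 nM in this assay, which is a limit of the assay. Among the compounds shown here, with compound 3 at the same limit, no step from compound 3 to compound 4 can be read: the limit of > 100000 nM in this assay, at which 3 of the 4 values shown sit. The compounds shown leave open whether chloro in place of hydrogen on an aromatic carbon lowers the number at all on the core of compound 3, as it does on the core of compound 1.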